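Swapping tert-Butyl for Trifluoromethyl on the Aryl Ring

The source may report more compounds than this note shows. Statements on the series, on what has been measured and on what is new or still open speak of the compounds shown alone.

Compound 1 `Cc1nc2cc(OC[C@H](O)CN3CCN(Cc4noc(-c5ccc(C(C)(C)C)cc5)n4)CC3)ccc2s1`: 180 nM
Compound 2 `Cc1nc2cc(OC[C@H](O)CN3CCN(Cc4noc(-c5ccc(C(C)C)cc5)n4)CC3)ccc2s1`: 950 nM
Compound 3 `Cc1nc2cc(OC[C@H](O)CN3CCN(Cc4nc(-c5ccc(C(C)(C)C)cc5)no4)CC3)ccc2s1`: 570 nM

In a functional assay on mitochondria from heart for inhibition of peroxisomal acyl-coenzyme A oxidase 1 (Rattus norvegicus) (a lower number here means a stronger inhibitor, a higher number a weaker inhibitor), compound 3 stands second highest of the three numbers, close to compound 2 and beyond the scatter from compound 1. Compound 4 `Cc1nc2cc(OC[C@H](O)CN3CCN(Cc4nc(-c5ccc(C(F)(F)F)cc5)no4)CC3)ccc2s1` differs from compound 3 by trifluoromethyl in place of tert-butyl on an aromatic carbon. For the measured compounds named here, the one measured step that bears on a change at this aromatic carbon is a 5.3-fold higher number from compound 1 to compound 2 (0.72 log units; beyond the scatter), where the group was also made smaller. Going by the values given here, no measured pair shows trifluoromethyl itself. A weaker inhibitor is therefore expected, and compound 4 is estimated at 1500 nM, within 500 nM to 5000 nM. The expected step is a 2.6-fold higher number from compound 3 to compound 4 (0.42 log units; beyond the scatter), judged from compound 1 to compound 2 a 5.3-fold higher number from compound 1 to compound 2 (0.72 log units; beyond the scatter).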

Compound 4, half-maximal inhibitory concentration: 3630 nM
For compound 4 the middle estimate is 2.4-fold (0.38 log units) below the measured one; the range from low to high includes it.
By their numbers in this assay, from the lowest: compound 1; then compounds 3 and 2 (each within the scatter of the next); then compound 4.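

In this assay the change at this aromatic carbon gives a 6.4-fold higher number from compound 3 to compound 4 (0.80 log units; beyond the scatter) even though tert-butyl and trifluoromethyl have the same heavy atom count and neither has a ring, donor or acceptor. The earlier step at this carbon also made the group smaller. This one shows that the number moves with the identity of the group even when that count stays the same.

On these data alone, whether an amine or a methoxy group at this carbon would fall nearer tert-butyl or trifluoromethyl remains open, as does the size of this same change in the core of compound 1. Nothing measured here gives a reason for the step.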